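Cyano for trifluoromethoxy on the aryl urea series

The source may hold more compounds than are shown below. What is called first, only, known or untested is meant among the compounds shown, and "the series" means these compounds.

Compound 2 `O=C(Nc1ccc(Cl)cc1)Nc1cc(C2CC2)nn1-c1ccc(OC(F)(F)F)cc1` and compound 1 `CC(C)(C)c1cc(NC(=O)Nc2ccc(Cl)cc2)n(-c2ccc(C#N)cc2)n1` share the same urea core. In an assay on isolated protein for inhibition of serine/threonine-protein kinase 10 (Homo sapiens), read by thermal shift assay, tested at 10 uM (a higher number here means that the compound stabilises the target more against heat, a lower number that the compound stabilises the target less), compound 2 gives 0 degrees C, the lowest of the two numbers; in this assay compound 1 gives 2.2 degrees C, a value beyond the scatter above it. Compound 3 `N#Cc1ccc(-n2nc(C3CC3)cc2NC(=O)Nc2ccc(Cl)cc2)cc1` has not yet been measured in this assay. The change from compound 2 to compound 3 is cyano in place of trifluoromethoxy on an aromatic carbon. Compound 1 also carries a cyano group and gives 2.2 degrees C in this assay. The step of a number 1.5 degrees C higher from compound 2 to compound 3 (beyond the scatter) is therefore expected to be small and positive. Compound 3 is expected to give 1.5 degrees C, within 0 degrees C to 3 degrees C.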

Compound 3, shift of the target's melting temperature: -0.7 degrees C
Beside the measured number, compound 3's estimate is 2.2 degrees C above it; the measured number lies below the stated range.
By their numbers in this assay, from the lowest: compounds 3 and 2 (each within the scatter of the next); then compound 1.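

In this assay the step of a number 0.70 degrees C lower from compound 2 to compound 3 (within the scatter) shows that, with cyclopropyl in place, cyano and trifluoromethoxy on this aromatic carbon are not told apart. With cyano held fixed, the step of a number 2.9 degrees C lower from compound 1 to compound 3 (beyond the scatter) ties the gain in compound 1 to tert-butyl rather than to cyano. Nothing at hand offers a reason for either step.

Still open, as far as these compounds go, is whether an amine or a carboxylic acid on this aromatic carbon would lift the number with cyclopropyl in place. Also open, from the compounds shown here alone, is whether trifluoromethoxy would match cyano with tert-butyl in place.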